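From Isopropyl to Ethoxymethyl: Estimating Compound 4

A few compounds are considered here, and "the series" means these few. Any claim that something is new, unique, unknown or untested is made for them only; others in the source may bear on it.

Of the compounds shown here, three built on one shared core have been tested in a functional assay on the whole organism (blood, strain Wistar-Okamoto) with Rattus norvegicus as the target, with a stated time of 5 days; on this read-out lower numbers stand for an effect already at smaller amounts and higher numbers for an effect only at larger amounts of compound. Compound 1 `CC(C)C/N=C(\NC#N)Nc1cccnc1` gives 20 mg/kg, the second highest of the three numbers. Compound 2 `CC(C)(C)C(C)(C)/N=C(\NC#N)Nc1cccnc1` gives 50 mg/kg, a higher number beyond the scatter, while compound 3 `CCC(CC)(CC)/N=C(\NC#N)Nc1cccnc1` gives 1 mg/kg, a much lower number, also beyond the scatter. Compound 4 `CCOCC/N=C(\NC#N)Nc1cccnc1` is not yet measured and differs from compound 1 in one place: ethoxymethyl in place of isopropyl on a saturated chain carbon bound to a double-bonded nitrogen. Within the data shown here, no measured pair shows a change of this kind, so nothing in the measured set points to a direction. A step of modest size, in either direction or none beyond the scatter, is expected: no change at the digits printed from compound 1 to compound 4 (within the scatter). Compound 4 is estimated to give 20 mg/kg, within a range from 5 mg/kg to 60 mg/kg.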

Compound 4, minimum effective dose: > 20 mg/kg
Compound 4: only a limit was reported; the forecaster's own chance of this, stated with the estimate: 10%; the middle value sits exactly at the limit.
By their numbers in this assay, from the lowest: compound 3; then compound 1; then compound 2.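

In this assay, ethoxymethyl in place of isopropyl on a saturated chain carbon bound to a double-bonded nitrogen gives a number no lower from compound 1 to compound 4 (the limit leaves the size open). The value of compound 4, > 20 mg/kg, is a limit and not a number. Among these compounds, the earlier compounds offered no pair differing in one place, so this is the only direct reading here: bringing an oxygen atom into this chain did not lower the number. As far as these compounds go, whether an amine, a carboxylic acid or a longer all-carbon chain at this place would lower the number stays open.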